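The source may hold more compounds than are shown below. What is called first, only, known or untested is meant among the compounds shown, and "the series" means these compounds.

Measured so far in an ADME assay on CEM-SS cells (Homo sapiens) for cytotoxicity, read by XTT assay, with a stated time of 6 days; on this read-out lower numbers stand for higher toxicity in this test and higher numbers for lower toxicity in this test:
- compound 1, `CCCC(=O)OCSc1ccccc1C(=O)NCCCCNC(C)=O`: compound 1 gives 17.4 uM
- compound 2, `CCCC(=O)OCSc1ccccc1C(=O)N[C@@H]1CCC[C@H]1C(N)=O`: compound 2 gives 43.7 uM
- compound 3, `CCCC(=O)OCSc1ccccc1C(=O)N[C@@H]1CCC[C@@H]1C(N)=O`: compound 3 gives 90 uM

Compound 1 has the lowest number of the three in this assay. The steps away from it are a 2.5-fold higher number from compound 1 to compound 2 (0.40 log units; beyond the scatter) and a 5.2-fold higher number from compound 1 to compound 3 (0.71 log units; beyond the scatter), both of which exchange the 4-acetamidobutyl chain for a 2-carbamoylcyclopentyl ring on the amide-type nitrogen. Between the two ring compounds the step is a 2.1-fold higher number from compound 2 to compound 3 (0.31 log units; beyond the scatter), and the fact that compounds 2 and 3 differ only in the configuration as drawn is all that separates them.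

Compound 4, `CCCCCNC(=O)CNC(=O)c1ccccc1SCOC(=O)CCC`, is not yet measured. Relative to compound 1 the change is pentylcarbamoyl in place of 3-acetamidopropyl on a saturated chain carbon bound to an amide-type nitrogen. This keeps an open chain on the amide-type nitrogen rather than closing it into a ring, so neither measured step maps onto it directly; the ring steps only show that the number can move upward from compound 1 by a modest amount when this part of the molecule is altered. For the measured compounds named here, no measured step speaks for a downward move. In this assay the expected step is therefore small, a 1.3-fold higher number from compound 1 to compound 4 (0.10 log units; within the scatter), with the direction open. Compound 4 is estimated at 22 uM, in the range 8 uM to 60 uM.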

Compound 4, half-maximal toxic concentration: 24.8 uM
Beside the measured number, compound 4's estimate is 1.1-fold (0.05 log units) below it, within the range that was stated.
By their numbers in this assay, from the lowest: compounds 1, 4 and 2 (each within the scatter of the next, the first and the last beyond it); then compound 3.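

In this assay, the exchange gives a 1.4-fold higher number from compound 1 to compound 4 (0.15 log units; within the scatter), so no shift can be read for pentylcarbamoyl in place of 3-acetamidopropyl on a saturated chain carbon bound to an amide-type nitrogen. Until now this part of the molecule had been seen to alter only through the 2-carbamoylcyclopentyl ring of compound 2 and compound 3, whose steps from compound 1 are beyond the scatter; compound 4 shows that an open-chain exchange at this place can leave the number within it. Nothing on hand bears on why this exchange stays within the scatter.

Open, going by these compounds, is whether an amine or a carboxylic acid in place of the pentylcarbamoyl group would also stay within the scatter of compound 1. On these data alone, a longer chain on the carbamoyl nitrogen is equally open.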